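Methyl on the aromatic ring of a weak triazine binder

A few compounds are considered here, and "the series" means these few. Any claim that something is new, unique, unknown or untested is made for them only; others in the source may bear on it.

Compound 1 `CCN(Cc1ccccc1)c1nc(C)nc(Nc2c(C)cccc2C)n1`: > 10000 nM
Compound 2 `CCCN(Cc1ccccc1)c1nc(C)nc(Nc2c(C)cccc2C)n1`: > 10000 nM
Compound 3 `C=CCN(CC=C)c1nc(C)nc(Nc2c(CC)cccc2CC)n1`: 5700 nM

In an assay on isolated protein for binding affinity to corticotropin-releasing factor receptor 1 (Homo sapiens) (a higher number here means a weaker inhibitor, a lower number a stronger inhibitor), compound 1 gives only a limit, > 10000 nM. Compound 2 likewise shows only a limit, > 10000 nM. Compound 3 gives a number, 5700 nM. The step that the two limits leave unreadable from compound 1 to compound 2 cannot be read, since both ends sit at the limit of > 10000 nM in this assay, at which 2 of the 3 values shown sit. Compound 4 `CCN(Cc1ccccc1)c1nc(C)nc(Nc2c(C)cc(C)cc2C)n1` differs from compound 1 by methyl in place of hydrogen on an aromatic carbon. No measured step among these compounds bears on this change, so the direction and size of the step in this assay are open. Compound 4 is therefore expected to stay close to the limit, with the step that the limit leaves unreadable from compound 1 to compound 4 estimated as small. The estimate for compound 4 is 12000 nM, within 3000 nM to 40000 nM.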

Compound 4, inhibition constant: 1470 nM
Compound 4: middle estimate off by 8.2-fold (0.91 log units), on the high side; measured number below the stated range.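

In this assay, for the compounds shown here, going from 2,6-dimethylphenyl to 2,4,6-trimethylphenyl gives an at least 6.8-fold lower number from compound 1 to compound 4 (0.83 log units; beyond the scatter) and so provides the first readable step here; the step from compound 1 to compound 2 cannot be read. A methyl on this aromatic carbon, para to a large group, thus brings the number clear of the limit. The size is only a minimum because compound 1 carries a limit: the limit of > 10000 nM in this assay, at which 2 of the 4 values shown sit.

Going by these compounds, it remains open whether an ethyl group, a methoxy group or a chlorine atom at this position would do the same. On these data alone, it is also open whether this methyl would lower the number on compound 2 or compound 3.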